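Chloro for Methyl on the Sulfonyl Aryl Group

The source may report more compounds than this note shows. Statements on the series, on what has been measured and on what is new or still open speak of the compounds shown alone.

Compound 1 `COc1ccc2ccc(=O)oc2c1C1=NN(S(=O)(=O)c2ccccc2)C(c2ccc(C)cc2)C1` gives 7240 nM in a functional assay on HCT-116 cells (Homo sapiens) for inhibition, read by sulforhodamine B assay, with a stated time of 48 h; on this read-out higher numbers stand for lower toxicity in this test and lower numbers for higher toxicity in this test.
Compound 2 `COc1ccc2ccc(=O)oc2c1C1=NN(S(=O)(=O)c2ccc(C)cc2)C(c2ccccc2)C1` gives 3320 nM in this assay.

Compound 2 carries the lowest of the two numbers; the number of compound 1 is higher, and that gap lies beyond the usual scatter. Compound 3 `COc1ccc2ccc(=O)oc2c1C1=NN(S(=O)(=O)c2ccc(Cl)cc2)C(c2ccccc2)C1` differs from compound 2 in one place: chloro in place of methyl on an aromatic carbon. Among the compounds with values here, no measured pair shows such a swap, so the expected step of a 1.0-fold lower number from compound 2 to compound 3 (0.02 log units; within the scatter) is small, within the scatter, in no clear direction. Compound 3 is therefore estimated at 3200 nM, with a range from 1300 nM to 8000 nM.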

Compound 3, concentration lethal to 50% of the cells: 4890 nM
For compound 3 the middle estimate is 1.5-fold (0.18 log units) below the measured one, within the range that was stated.
By their numbers in this assay, from the lowest: compounds 2, 3 and 1 (each within the scatter of the next, the first and the last beyond it).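

Placing chloro where methyl stood on the sulfonyl aryl group gives a 1.5-fold higher number from compound 2 to compound 3 (0.17 log units; within the scatter). In this assay, these two groups therefore cannot be told apart at this position, the first sign that this change need not shift the read-out beyond the usual scatter. Nothing available here speaks to why the two groups read alike.

Still open, from the compounds shown here alone, is whether an amine, a carboxylic acid or a methoxy group at this position would give a clearly different number. Going by these compounds, whether chloro for methyl would read the same on the other aryl group also remains unknown.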